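Benzyloxyphenyl series: swapping the pendant aryl group

A few compounds are considered here, and "the series" means these few. Any claim that something is new, unique, unknown or untested is made for them only; others in the source may bear on it.

Measured so far:
compound 1 `COc1cccc(COc2ccc(-c3nn(CCC#N)c(=S)o3)cc2)c1`: 100 nM
compound 2 `COc1cccc(COc2ccc(C3=NN(CCC#N)C(=O)CO3)cc2)c1`: 68 nM

Both compounds were run in an assay for inhibition of Amine oxidase [flavin-containing] B (Rattus norvegicus); on this read-out lower numbers stand for stronger inhibition and higher numbers for weaker inhibition. Compound 2 holds the lower of the two numbers, but its gap to compound 1 sits within the usual scatter of this assay, so the two read as indistinguishable. Within the data shown here, the two compounds also differ in their cores, and no pair differing in a single place is available, so nothing is inferred about either core.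

Compound 3 `N#CCCN1N=C(c2ccc(OCc3ccc([N+](=O)[O-])cc3)cc2)OCC1=O` keeps the core of compound 2 and differs from it by 4-nitrophenyl in place of 3-methoxyphenyl on a saturated chain carbon bound to an oxygen on an aromatic ring. Among the measured compounds shown here, no measured pair isolates this change, so the expectation rests on compound 2 alone and on the absence of any large swing between the two measured compounds. The expected step from compound 2 to compound 3 in this assay is a 1.2-fold lower number from compound 2 to compound 3 (0.09 log units; within the scatter), a shift not clearly beyond the scatter. Compound 3 is estimated at 55 nM, with a range from 15 nM to 200 nM.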

Compound 3, half-maximal inhibitory concentration: 300 nM
Estimate against measurement, compound 3: 5.5-fold (0.74 log units) below; measured number outside the range, above it.
By their numbers in this assay, from the lowest: compounds 2 and 1 (each within the scatter of the next); then compound 3.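

Among these compounds, this is the first pair that differs in one place, and it shows that in this assay the read-out responds to the aryl group on a saturated chain carbon bound to an oxygen on an aromatic ring. Placing 4-nitrophenyl in place of 3-methoxyphenyl on the core of compound 2 gives a 4.4-fold higher number from compound 2 to compound 3 (0.64 log units; beyond the scatter) and so this position does not tolerate every aryl group equally. No measurement at hand bears on why the number rises.

As far as these compounds go, a single pair cannot separate the loss of the 3-methoxy group from the arrival of the 4-nitro group, so it remains open whether unsubstituted phenyl, 4-methoxyphenyl or 3-nitrophenyl would read closer to compound 2 or to compound 3. From the compounds shown here alone, whether the same swap on the core of compound 1 gives a similar step also stays open.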